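The source may report more compounds than this note shows. Statements on the series, on what has been measured and on what is new or still open speak of the compounds shown alone.

Measured in an ADME assay on RAW264.7 cells (Mus musculus) for cytotoxicity, read by MTT assay; on this read-out lower numbers stand for stronger inhibition and higher numbers for weaker inhibition:
Compound 1 `Cc1cc(C(=O)/C=C/C=C/c2ccccc2)c(C)o1` gives > 100000 nM, which is a limit of the assay.
Compound 2 `COc1ccc(/C=C/C=C/C(=O)c2cc(C)oc2C)cc1` gives > 100000 nM, which is a limit of the assay.
Compound 3 `CN(C)c1ccc(/C=C/C=C/C(=O)c2ccccc2)cc1` gives > 100000 nM, which is a limit of the assay.

The change from compound 1 to compound 2 is methoxy in place of hydrogen on an aromatic carbon. The step it made is a step that the two limits leave unreadable from compound 1 to compound 2, because every value shown sits at the limit of > 100000 nM in this assay, at which 3 of the 3 values shown sit.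

Compound 4 `COc1ccc(C(=O)/C=C/C=C/c2ccc(N(C)C)cc2)cc1` has not yet been measured. It differs from compound 3 by methoxy in place of hydrogen on an aromatic carbon, the same change as from compound 1 to compound 2. The cores of compound 1 and compound 3 differ, and that difference is not broken down here.

Within the data shown here, compound 4 is expected to give about 150000 nM, most likely again as a limit, because the one earlier example of this change is a step that the two limits leave unreadable from compound 1 to compound 2. The step from compound 3 to compound 4 is accordingly estimated as a step that the limit leaves unreadable from compound 3 to compound 4.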

Compound 4, half-maximal inhibitory concentration: > 100000 nM
Compound 4: no number, only a limit (the forecaster's own chance of this, stated with the estimate: 85%); the middle value is on the limit's open side.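

No step can be read from compound 3 to compound 4, since both give only a limit: the limit of > 100000 nM in this assay, at which 4 of the 4 values shown sit. The compounds shown leave open how far any of them lies past that limit, and so whether methoxy in place of hydrogen changes the result in this assay at all.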